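The compounds below may be only part of what the source reports. "The series", "measured", "known", "first", "only" and "open" are said of these compounds alone.

Series values in a functional assay on HepG2 cells (Homo sapiens) for cytotoxicity, read by MTT assay, with a stated time of 24 h; a lower number here means a stronger inhibitor, a higher number a weaker inhibitor

- compound 1 `CN1C/C(=C\c2ccncc2)C(=O)/C(=C/c2cc([N+](=O)[O-])ccc2F)C1` gives 5200 nM
- compound 2 `CN1C/C(=C\c2ccncc2)C(=O)/C(=C/c2ccccc2C(F)(F)F)C1` gives 3300 nM
- compound 3 `O=C1/C(=C/c2cccnc2)CN(S(=O)(=O)c2ccccc2)C/C1=C\c1ccccc1F` gives 8210 nM

Compound 3 at 8210 nM lies within the scatter of compound 1 at 5200 nM. Compound 2 at 3300 nM has a lower number than compound 3, and that gap lies beyond the scatter. With only these three numbers, the series gives a narrow view of this assay.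

The next compound is compound 4 `O=C1/C(=C/c2cccnc2)CN(S(=O)(=O)c2ccc(Cl)cc2)C/C1=C\c1ccccc1F`, which keeps the structure of compound 3 except for one change: chloro in place of hydrogen on an aromatic carbon, turning phenylsulfonyl into (4-chlorophenyl)sulfonyl (chloro in place of hydrogen on an aromatic carbon). The new atom sits on a six-membered aromatic ring of carbon only, para to a large group.

Going by the values given here, no measured pair differs in one place, so the data hold no direct reading of this change. Compound 3 at 8210 nM is the only anchor for the expectation. The estimated step of a 1.4-fold lower number from compound 3 to compound 4 (0.14 log units; within the scatter) is small, leans toward a lower number and is expected to stay within the scatter. For compound 4 the expected value is 6000 nM, with an estimated range from 2500 nM to 12000 nM.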

Compound 4, half-maximal inhibitory concentration: 12400 nM
Compound 4: the middle estimate sits 2.1-fold (0.32 log units) below what was measured; measured number outside the range, above it.
By their numbers in this assay, from the lowest: compounds 2, 1, 3 and 4 (each within the scatter of the next, the first and the last beyond it).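

Going by these compounds alone, the step of a 1.5-fold higher number from compound 3 to compound 4 (0.18 log units; within the scatter) gives the first single-place reading in this assay, and it shows no separation between the two compounds. At this place, on a six-membered aromatic ring of carbon only and para to a large group, turning phenylsulfonyl into (4-chlorophenyl)sulfonyl therefore leaves the read-out within the usual spread of repeated measurements, a finding that rests on this one pair alone. No measured property of these compounds bears on the result, so the step stands without an explanation.

On these data alone, whether the same flat reading holds for other groups at this place remains open, since a methoxy group, an amine or a carboxylic acid in place of the chloro would test the position with a different kind of substituent. Steps linking compound 1 or compound 2 to this pair cannot be read, as those compounds differ from it in more than one place, so it is also open whether chloro in place of hydrogen gives a similar step on another version of the core.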